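Ester variation on the shared core: isopropyl to butyl

The compounds below may be only part of what the source reports. "The series", "measured", "known", "first", "only" and "open" are said of these compounds alone.

Two compounds carry measured numbers. Compound 1 `CCOC(=O)[C@@]12C[C@@H]1[C@@H](n1cnc3c(NC)nc(C#Cc4ccc(Cl)s4)cc31)[C@H](O)[C@@H]2O` and compound 2 `CNc1nc(C#Cc2ccc(Cl)s2)nc2c1ncn2[C@H]1[C@H](O)[C@H](O)[C@]2(C(=O)OC(C)C)C[C@H]12` differ in more than one place, so only their values are compared here. In an assay on cells for displacement of a labelled ligand from adenosine receptor A3 (Mus musculus), read by scintillation counting and radioligand binding, with stated times of 10 min and 90 min, tested at 10 uM (on this read-out higher numbers stand for more inhibition at the one concentration tested (going by the name of the read-out) and lower numbers for less inhibition), compound 1 gives 18%, and in this assay compound 2 gives 30%. Compound 2 therefore stands highest of the two numbers, and its nearest neighbour, compound 1, lies beyond the scatter below it.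

Compound 3 `CCCCOC(=O)[C@@]12C[C@@H]1[C@@H](n1cnc3c(NC)nc(C#Cc4ccc(Cl)s4)nc31)[C@H](O)[C@@H]2O` is not yet measured. It differs from compound 2 in one place: butyl in place of isopropyl on an oxygen next to a carbonyl group. The change is butyl in place of isopropyl on an oxygen next to a carbonyl group, with no ring, no donors or acceptors and no charge entering or leaving.

Among the measured compounds shown here, no measured pair shows what lengthening this ester chain does, so the expectation rests on compound 2 alone. The step from compound 2 to compound 3 is expected to be a number 2 percentage points lower from compound 2 to compound 3 (within the scatter), that is, none beyond the scatter in either direction. In this assay compound 3 is accordingly estimated at 28%, with a range from 10% to 48%.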

Compound 3, a percentage reported as inhibition, at one concentration (the size of the read-out at that concentration, not a potency): 54%
Beside the measured number, compound 3's estimate is 26 percentage points below it; the whole stated range lies below it.
By their numbers in this assay, from the lowest: compound 1; then compound 2; then compound 3.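

In this assay, among the compounds shown here, the ester position proves responsive: butyl in place of isopropyl on an oxygen next to a carbonyl group gives a number 24 percentage points higher from compound 2 to compound 3 (beyond the scatter), the only single-place step so far and one that lies beyond the scatter. The position is therefore not indifferent to the group on the ester oxygen, even though the change brings in no ring, no donors or acceptors and no charge. No measurement at hand bears on what lies behind this step.

As far as these compounds go, a single step cannot separate the effect of a longer chain from that of losing the branch, so it remains open whether an unbranched propyl ester would already read like compound 3 or a branched isobutyl ester like compound 2. Also open, from the compounds shown here alone, is whether the trend continues to a longer chain such as hexyl or ends there, and how a carboxylic acid or an amide at the same place would read, all the more as these numbers are inhibition at one concentration and not potencies.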